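A few compounds are considered here, and "the series" means these few. Any claim that something is new, unique, unknown or untested is made for them only; others in the source may bear on it.

Compound 1 `CCn1cc(-c2nc3ccccc3[nH]2)c(=O)c2cc(F)c(N3CCNCC3)cc21` and compound 2 `CCn1cc(-c2nc3ccccc3o2)c(=O)c2cc(F)c(Cl)cc21` share a piece of their framework but differ in more than one place; how their two cores differ is not broken down here. In a functional assay on KB cells (Homo sapiens) for cytotoxicity, read by MTT assay, with a stated time of 48 h (on this read-out lower numbers stand for stronger inhibition and higher numbers for weaker inhibition), compound 1 gives 10500 nM, and compound 2 gives 10200 nM, two numbers that sit within the usual scatter of one another. Compound 3 `CCn1cc(-c2nc3ccc([N+](=O)[O-])cc3[nH]2)c(=O)c2cc(F)c(N3CCNCC3)cc21` carries on the core of compound 1 a single alteration, (nitro in place of hydrogen on an aromatic carbon), and in this assay compound 3 gives 1100 nM, so that the step of a 9.5-fold lower number from compound 1 to compound 3 (0.98 log units; beyond the scatter) is the one clear movement among the three measured compounds. Compound 4 `CCn1cc(-c2nc3ccc([N+](=O)[O-])cc3o2)c(=O)c2cc(F)c(Cl)cc21` is built from compound 2 by the same change, (nitro in place of hydrogen on an aromatic carbon), made at a place described in the same words as for compound 3. Since that change on the core of compound 1 produced the step already told, the step from compound 2 to compound 4 is expected to be of a similar size, a 6.8-fold lower number from compound 2 to compound 4 (0.83 log units; beyond the scatter), resting on that single earlier example only. Compound 4 is therefore expected to give about 1500 nM, most likely between 500 nM and 5000 nM.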

Compound 4, half-maximal inhibitory concentration: 500 nM
For compound 4 the middle estimate is 3.0-fold (0.48 log units) above the measured one, and the stated range covers the measured number.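

The new step in this assay is a 20-fold lower number from compound 2 to compound 4 (1.31 log units; beyond the scatter), and it runs in the same direction as the step seen on the core of compound 1. Set side by side, the two steps do not differ beyond what repeated measurements allow, so in this assay nitro in place of hydrogen on an aromatic carbon carried over from one core to the other: the same change on two cores in this assay, a 9.5-fold lower number (0.98 log units; beyond the scatter) from compound 1 to compound 3 and a 20-fold lower number (1.31 log units; beyond the scatter) from compound 2 to compound 4, 2.1-fold (0.33 log units) apart, within the scatter of two such steps. Among the compounds shown here, this rests on only two pairs of compounds in a single cell assay, so it does not show that the change would carry over to any other core, and it does not explain why the numbers fall.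

The compounds shown leave open whether an amine or a carboxylic acid on the same aromatic carbon would move the number as nitro does. They also leave open whether nitro would give a similar step on other carbons of that six-membered ring, or in other cells.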